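Fluoro in place of hydrogen: compound 3 to compound 4

This account rests on a few compounds, and the source may have more. Where it says the series, first, only, none or still open, it means among the compounds named here.

Compound 3 `O=C(Nc1ccc(Oc2ccnc3[nH]ccc23)cc1)c1cc(-c2ccccc2)ccn1` gives 3270 nM in a functional assay on PC-3 cells (Homo sapiens) for cytotoxicity, read by MTT assay, with a stated time of 72 h (a higher number here means a weaker inhibitor, a lower number a stronger inhibitor), the lowest of the two numbers shown. Compound 2 `O=C(Nc1ccc(Oc2ccnc3[nH]ccc23)cc1)c1cc(-c2ccc(C(F)(F)F)cc2)ccn1` gives 14200 nM in this assay, and the step of a 4.3-fold lower number from compound 2 to compound 3 (0.64 log units; beyond the scatter) lies beyond the scatter. Compound 1 `Cc1ccc(-c2ccnc(C(=O)Nc3ccc(Oc4ccnc5[nH]ccc45)cc3)c2)cc1` sits at the limit of this assay, (the limit of > 10000 nM in this assay, at which 1 of the 3 values shown sits), so compound 1 gives only > 10000 nM and no number. The steps a step that the limit leaves unreadable from compound 1 to compound 2 and an at least 3.0-fold lower number from compound 1 to compound 3 (0.48 log units; beyond the scatter) therefore rest on that limit and are read only in part.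

Compound 4 `O=C(Nc1ccc(Oc2ccnc3[nH]ccc23)c(F)c1)c1cc(-c2ccccc2)ccn1` differs from compound 3 by fluoro in place of hydrogen on an aromatic carbon. Going by the values given here, no measured step touches this ring: the three measured steps all exchange the group on the other aromatic ring, and the readable one is modest. They bear on compound 4 only indirectly, showing that a single-group change on an aromatic carbon in this series has moved the numbers modestly, not strongly. For compound 4 the expected step in this assay is a 1.0-fold higher number from compound 3 to compound 4 (0.00 log units; within the scatter), within the scatter. The estimate for compound 4 in this assay is 3300 nM, between 1300 nM and 8500 nM.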

Compound 4, half-maximal inhibitory concentration: > 10000 nM
Compound 4: only a limit was reported; the forecaster's own chance of this, stated with the estimate: 10%; middle value at least 3.0-fold (0.48 log units) away from the limit.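

In this assay, going by these compounds alone, fluoro in place of hydrogen on this aromatic carbon, ortho to a large group and meta to a large group, gives an at least 3.0-fold higher number from compound 3 to compound 4 (0.48 log units; beyond the scatter), the first readable change on this ring, since the earlier steps all exchanged the group on the other aromatic ring. Compound 4 gives > 10000 nM, which is a limit of the assay and not a number. Compound 3 keeps the lowest number of the four, and the full size of its step to compound 4 stays unread because the reading stops at a limit: the limit of > 10000 nM in this assay, at which 2 of the 4 values shown sit.

The compounds shown leave open whether this rise belongs to fluoro itself or would follow other groups on this carbon, such as chloro, methoxy or an amine. Also open, as far as these compounds go, is how fluoro here reads when the other aromatic ring carries methyl or trifluoromethyl, as in compound 1 and compound 2.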